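The source may report more compounds than this note shows. Statements on the series, on what has been measured and on what is new or still open speak of the compounds shown alone.

Of the compounds shown here, three have numbers so far in an in vivo ADME assay on the whole organism (plasma, Rattus norvegicus) for pharmacokinetics; on this read-out lower numbers stand for slow clearance and higher numbers for fast clearance. Compound 1 (`NS(=O)(=O)c1ccccc1-c1ccc(C(=O)NCCC(=O)Nc2ccc(Br)cn2)cc1`) gives 35 mL/min/kg, compound 2 (`NS(=O)(=O)c1ccccc1-c1ccc(C(=O)NC(CC(=O)Nc2ccc(Br)cn2)C(=O)N2CCCCC2)cc1`) gives 50.6 mL/min/kg, and compound 3 (`CN(C)Cc1ccccc1-c1ccc(C(=O)N[C@@H](CC(=O)Nc2ccc(Cl)cn2)C(=O)N2CCCCC2)cc1`) gives 124 mL/min/kg. Compound 3 therefore stands highest of the three, beyond the scatter of both others.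

Next in line is compound 4 (`CN(C)Cc1ccccc1-c1ccc(C(=O)N[C@H](CC(=O)Nc2ccc(Cl)cn2)C(=O)N2CCCCC2)cc1`). Its difference from compound 3 is this: the two compounds have the same atoms and bonds and differ only in configuration as drawn: 1 of 1 stereo elements differ; a stereocentre at a saturated chain carbon is drawn S in compound 3 and R in compound 4. No atoms leave or enter, and only the drawing of that stereocentre at a saturated chain carbon changes.

Among the measured compounds shown here, the only measured step available is a 1.4-fold higher number from compound 1 to compound 2 (0.16 log units; within the scatter), which lies within the scatter. That step places (piperidin-1-yl)carbonyl in place of hydrogen on a saturated chain carbon, so it is a change of atoms and not of configuration. It bears on the present question only loosely. For the measured compounds named here, no measured pair differs in configuration alone, so the data give no direct size for such a change.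

No step beyond the scatter is therefore expected in this assay, with a slight lean towards a lower number, as compound 3 is the top of the three. The expected change is a 1.2-fold lower number from compound 3 to compound 4 (0.09 log units; within the scatter). For compound 4 the estimate is 100 mL/min/kg, with an expected range from 50 mL/min/kg to 170 mL/min/kg.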

Compound 4, clearance: 178 mL/min/kg
Estimate against measurement, compound 4: 1.8-fold (0.25 log units) below; measured number above the stated range.
By their numbers in this assay, from the lowest: compounds 1 and 2 (each within the scatter of the next); then compounds 3 and 4 (each within the scatter of the next).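

In this assay, among the compounds shown here, a 1.4-fold higher number from compound 3 to compound 4 (0.16 log units; within the scatter) gives the first reading of configuration alone at this saturated chain carbon, and that step lies within the scatter. The earlier step, a 1.4-fold higher number from compound 1 to compound 2 (0.16 log units; within the scatter), also within the scatter, concerned placing (piperidin-1-yl)carbonyl on a saturated chain carbon, a change of atoms, and gave no size for swapping S and R once that group is present. In this one pair, the drawn configuration at the stereocentre does not separate the two numbers beyond the scatter, and no other structural change has to be allowed for in reading the step: the fact that compounds 3 and 4 differ only in the configuration as drawn.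

On these data alone, this pair shares a single background, so it stays open whether configuration at this carbon would count for as little in a compound carrying the sulfonamide of compound 2. Also open, as far as these compounds go, is whether the same holds with a carboxylic acid or a morpholine amide in place of the (piperidin-1-yl)carbonyl, where the stereocentre would carry a different group.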